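Octyl-phenoxy ketones: small tetrazole in place of benzimidazole

The source may hold more compounds than are shown below. What is called first, only, known or untested is meant among the compounds shown, and "the series" means these compounds.

Measured so far:
compound 1 `CCCCCCCCc1ccc(OCC(=O)Cn2cnc3ccccc32)cc1` — 480 nM
compound 2 `CCCCCCCCc1ccc(OCC(=O)Cn2ncc3cccnc32)cc1` — 1600 nM
compound 3 `CCCCCCCCc1ccc(OCC(=O)Cn2cnnn2)cc1` — 39 nM

All three share the same core and are tested in an assay on microsomes from brain for inhibition of Fatty-acid amide hydrolase 1 (Rattus norvegicus), read by fluorescence and HPLC, with a stated time of 60 min; on this read-out higher numbers stand for weaker inhibition and lower numbers for stronger inhibition. Compound 1 stands second highest of the three numbers: compound 2 sits above it, with a 3.3-fold higher number from compound 1 to compound 2 (0.52 log units; beyond the scatter), while compound 3 sits well below it, with a 12-fold lower number from compound 1 to compound 3 (1.09 log units; beyond the scatter). The gap from compound 2 down to compound 3 is the widest in the set, a 41-fold lower number from compound 2 to compound 3 (1.61 log units; beyond the scatter).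

Compound 4 `CCCCCCCCc1ccc(OCC(=O)Cn2ncnn2)cc1` is not yet measured. Against compound 1 the change is 2H-tetrazol-2-yl in place of 1H-benzimidazol-1-yl on a saturated chain carbon bound to a carbonyl carbon. Going by the values given here, the step that bears most directly on it is the one from compound 1 to compound 3, where the related 1H-tetrazol-1-yl replaced the same 1H-benzimidazol-1-yl and produced a large drop in the number. Among the compounds with values here, compound 4 carries the same small ring attached through a different nitrogen, and the data give no step that separates the two tetrazole attachments, so the expectation rests on compound 3 alone, because 39 nM is the only number for a tetrazole. A sizeable decrease in the number is therefore expected, an 8.0-fold lower number from compound 1 to compound 4 (0.90 log units; beyond the scatter), though with a wider range than the measured step. The estimate for compound 4 in this assay is 60 nM, between 15 nM and 250 nM.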

Compound 4, half-maximal inhibitory concentration: 10 nM
The estimate for compound 4 lay 6.0-fold (0.78 log units) above the measured number; measured number below the stated range.
By their numbers in this assay, from the lowest: compound 4; then compound 3; then compound 1; then compound 2.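

In this assay, going by these compounds alone, the point of attachment of the tetrazole matters on this saturated chain carbon bound to a carbonyl carbon: 2H-tetrazol-2-yl in place of 1H-tetrazol-1-yl gives a modest step beyond the scatter (a 3.9-fold lower number from compound 3 to compound 4 (0.59 log units; beyond the scatter)), which the earlier compounds could not show. The large gain over the fused rings is therefore not confined to one tetrazole, and it widens with this attachment, both against the 1H-benzimidazol-1-yl group (a 48-fold lower number from compound 1 to compound 4 (1.68 log units; beyond the scatter)) and against the fused ring with three nitrogens (a 160-fold lower number from compound 2 to compound 4 (2.20 log units; beyond the scatter)). Nothing in the available data accounts for the difference between the two attachments.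

The compounds shown do not separate the loss of the fused six-membered ring from the gain in ring nitrogens, a question that 1H-imidazol-1-yl and 1H-1,2,4-triazol-1-yl would bear on directly. Also open, going by these compounds, are whether 2H-tetrazol-2-yl tolerates a methyl group or a carboxylic acid as a substituent, and whether the gap between the two tetrazole attachments persists with a hexyl chain in place of the octyl chain.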